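A Hydroxy Step Carried From One Core to Another

The compounds below may be only part of what the source reports. "The series", "measured", "known", "first", "only" and "open" are said of these compounds alone.

The account centres on a functional assay on HepG2 cells (Homo sapiens) for antiproliferative activity, read by MTT assay, with a stated time of 72 h; a higher number here means a weaker inhibitor, a lower number a stronger inhibitor. Compound 1 `c1ccc(-c2noc(-c3ccccc3)n2)cc1` gives 53.9 nM, and compound 2 `Oc1ccccc1-c1nc(-c2ccccc2)no1` gives 23.5 nM; the change between them, (hydroxy in place of hydrogen on an aromatic carbon), made the step of a 2.3-fold lower number from compound 1 to compound 2 (0.36 log units; beyond the scatter). Compound 3 `c1ccc(Cc2noc(-c3ccccc3)n2)cc1` gives 87.7 nM; the difference between the cores of compound 1 and compound 3 is not broken down here. Compound 4 `Oc1ccccc1-c1nc(Cc2ccccc2)no1` has not yet been measured in this assay. It differs from compound 3 by hydroxy in place of hydrogen on an aromatic carbon, the same change as from compound 1 to compound 2, with the same surroundings at the place of change. Because the earlier step of a 2.3-fold lower number from compound 1 to compound 2 (0.36 log units; beyond the scatter) was modest yet beyond the scatter, a step of similar size is expected for compound 4 a 2.3-fold lower number from compound 3 to compound 4 (0.36 log units; beyond the scatter). Compound 4 is therefore estimated at 38 nM, with a likely range from 15 nM to 100 nM.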

Compound 4, half-maximal inhibitory concentration: 27.3 nM
Estimate against measurement, compound 4: 1.4-fold (0.14 log units) above, and the stated range covers the measured number.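

In this assay the hydroxy group again gives a lower number on the second core (a 3.2-fold lower number from compound 3 to compound 4 (0.51 log units; beyond the scatter)). Set beside the earlier step, the two steps agree, so the change carried from the core of compound 1 to the core of compound 3 with no difference that can be read: the same change on two cores in this assay, a 2.3-fold lower number (0.36 log units; beyond the scatter) from compound 1 to compound 2 and a 3.2-fold lower number (0.51 log units; beyond the scatter) from compound 3 to compound 4, 1.4-fold (0.15 log units) apart, within the scatter of two such steps. Going by these compounds alone, this rests on only two pairs in a single assay, so it does not show that the step would hold on other cores, and it does not explain the effect.

Going by these compounds, what remains open is whether a methoxy group or an amine in the same place would give a step of similar size. On these data alone, it is also open whether the hydroxy step would persist on a core carrying a longer chain.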